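The source may report more compounds than this note shows. Statements on the series, on what has been measured and on what is new or still open speak of the compounds shown alone.

In a functional assay on HeLa cells (Homo sapiens) for inhibition, read by CCK-8 assay, with a stated time of 48 h (on this read-out higher numbers stand for weaker inhibition and lower numbers for stronger inhibition), three compounds have been measured:

Compound 1, `COc1ccc(C2=NN(C3=NC(c4ccccc4)CS3)C(c3cccc4ccccc34)C2)cc1`, gives 3310 nM.
Compound 2, `c1ccc(C2=NN(C3=NC(c4ccccc4)CS3)C(c3cccc4ccccc34)C2)cc1`, gives 5320 nM.
Compound 3, `Cc1ccc(C2=NN(C3=NC(c4ccccc4)CS3)C(c3ccc4ccccc4c3)C2)cc1`, gives 2460 nM.

Compound 2 carries the highest of these three numbers. Its nearest neighbour is compound 1, whose number lies within the scatter of that of compound 2; the furthest is compound 3, whose number is lower by more than the scatter, though compound 3 differs from compound 2 in more than one place, so the two values are only set side by side here.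

Compound 4, `Fc1ccc(C2=NN(C3=NC(c4ccccc4)CS3)C(c3cccc4ccccc34)C2)cc1`, has not yet been measured. It differs from compound 2 by fluoro in place of hydrogen on an aromatic carbon.

Among the compounds with values here, the one measured step that bears on this position is a 1.6-fold higher number from compound 1 to compound 2 (0.21 log units; within the scatter), where a substituent at the same place was removed and the number barely moved. On that evidence a single small substituent added at this place is expected to give a step of a 1.3-fold lower number from compound 2 to compound 4 (0.12 log units; within the scatter) in this assay, that is, nothing beyond the scatter. Compound 4 is therefore estimated at 4000 nM, with a range from 1800 nM to 9000 nM.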

Compound 4, half-maximal inhibitory concentration: 12400 nM
For compound 4 the middle estimate is 3.1-fold (0.49 log units) below the measured one, outside the stated range (above it).
By their numbers in this assay, from the lowest: compounds 3, 1 and 2 (each within the scatter of the next, the first and the last beyond it); then compound 4.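

In this assay, the change from phenyl to 4-fluorophenyl gives a 2.3-fold higher number from compound 2 to compound 4 (0.37 log units; beyond the scatter), so this place on the ring, which had seemed tolerant while the exchange of methoxy for hydrogen stayed within the scatter, does respond to a substituent of a single heavy atom. Fluoro also stands apart from methoxy, with a 3.7-fold higher number from compound 1 to compound 4 (0.57 log units; beyond the scatter), so the three substituents do not behave alike here: compound 1 and compound 2 remain within the scatter of each other, while compound 4 alone lies beyond the scatter of both, by steps of modest size. The data shown offer no measurement that accounts for this difference.

Within the data shown here, whether the higher number is particular to fluoro or would recur with chloro, hydroxyl, an amine or a carboxylic acid at this place remains open, since hydrogen, methoxy and fluoro are the only groups compared there on this core. On these data alone, compound 3 differs from these compounds in more than one place, so the effect of a methyl group on the core of compound 2 also remains open.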